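This account rests on a few compounds, and the source may have more. Where it says the series, first, only, none or still open, it means among the compounds named here.

Measured so far:
Compound 1, `COc1cccc(/C=C/C(=O)c2ccccc2NC(=O)NS(=O)(=O)c2ccc(C)cc2)c1`: in an ADME assay on the whole organism for cytotoxicity, with Artemia salina as the target, with a stated time of 24 h (on this read-out higher numbers stand for an effect only at larger amounts of compound and lower numbers for an effect already at smaller amounts), compound 1 gives 23.2 ug/mL.
Compound 2, `Cc1ccc(S(=O)(=O)NC(=O)Nc2ccccc2C(=O)/C=C/c2ccccc2[N+](=O)[O-])cc1`: in this assay compound 2 gives 40.1 ug/mL.

Of the two numbers at hand, that of compound 2 is the larger on paper, but the step of a 1.7-fold higher number from compound 1 to compound 2 (0.24 log units; within the scatter) lies within the scatter, so the two compounds cannot be told apart by this read-out. Compound 3, `Cc1ccc(S(=O)(=O)NC(=O)Nc2ccccc2C(=O)/C=C/c2ccncc2)cc1`, has not yet been measured in this assay. It differs from compound 2 in one place: pyridin-4-yl in place of 2-nitrophenyl on a double-bonded chain carbon bound to a double-bonded chain carbon. Among the measured compounds shown here, only one measured step bears on this, a 1.7-fold higher number from compound 1 to compound 2 (0.24 log units; within the scatter), which also exchanges the group on a double-bonded chain carbon bound to a double-bonded chain carbon, there from 3-methoxyphenyl to 2-nitrophenyl, and it stayed within the scatter. For the measured compounds named here, no measured step involving pyridin-4-yl exists. On this basis the expected step is a 1.1-fold lower number from compound 2 to compound 3 (0.06 log units; within the scatter), a move not expected to go beyond the scatter in either direction. Compound 3 is therefore estimated at 35 ug/mL in this assay, with a range from 15 ug/mL to 80 ug/mL.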

Compound 3, concentration for half-maximal effect: 16.8 ug/mL
Estimate against measurement, compound 3: 2.1-fold (0.32 log units) above, and the stated range covers the measured number.
By their numbers in this assay, from the lowest: compounds 3, 1 and 2 (each within the scatter of the next, the first and the last beyond it).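

In this assay, among the compounds shown here, putting pyridin-4-yl in place of 2-nitrophenyl on a double-bonded chain carbon bound to a double-bonded chain carbon gives a 2.4-fold lower number from compound 2 to compound 3 (0.38 log units; beyond the scatter), the first step at this place that goes beyond the scatter, which shows that the group held here can shift the read-out, if only modestly. For the compounds shown here, the same entering group set against 3-methoxyphenyl gives a 1.4-fold lower number from compound 1 to compound 3 (0.14 log units; within the scatter), so compound 1 cannot be told apart from either of the other two, and the only separated pair is compound 2 and compound 3. Nothing available on these compounds accounts for the step between that pair.

On these data alone, all three compounds carry a six-membered aromatic ring at this place, so it remains open whether an unsubstituted phenyl or a pyridin-3-yl would fall with compound 3, with compound 2 or between them, and whether a saturated cyclohexyl ring would keep the number in the same range. Also open, as far as these compounds go, is whether the step from 2-nitrophenyl to pyridin-4-yl would recur with a different group on the sulfonyl side of the shared core, such as a plain phenyl or a 4-chlorophenyl.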